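Three chlorinated benzimidazoles and a fourth yet to be tested

The source may hold more compounds than are shown below. What is called first, only, known or untested is meant among the compounds shown, and "the series" means these compounds.

Compound 1 `Clc1ccc(Cn2c(Cl)nc3cc(Cl)c(Cl)cc32)cc1Cl` gives > 100000 nM in a functional assay on CEM-SS cells (Homo sapiens) for cytotoxicity; a lower number here means a stronger inhibitor, a higher number a weaker inhibitor; this is a limit of the assay.
Compound 2 `Clc1cccc(Cn2c(Cl)nc3cc(Cl)c(Cl)cc32)c1` gives > 100000 nM in this assay; this too is a limit.
Compound 3 `Clc1cc2nc(Br)n(Cc3ccccc3)c2cc1Cl` gives > 100000 nM in this assay; again a limit.

Compound 2 and compound 1 differ by chloro in place of hydrogen on an aromatic carbon, and the step that the two limits leave unreadable from compound 2 to compound 1 cannot be read because of the limit of > 100000 nM in this assay, at which 3 of the 3 values shown sit. The difference between the cores of compound 3 and compound 2 is not broken down here. Compound 4 `Clc1cc2nc(Br)n(Cc3ccccc3Cl)c2cc1Cl` is not yet measured; it differs from compound 3 by chloro in place of hydrogen on an aromatic carbon, the same kind of change as that from compound 2 to compound 1, though here the entering chloro sits ortho to a large group rather than ortho to a chloro group and para to a large group. Compound 4 is expected to sit at the limit as well, a step that the limit leaves unreadable from compound 3 to compound 4, because of the limit of > 100000 nM in this assay, at which 3 of the 3 values shown sit. The estimate for compound 4 is 150000 nM, between 60000 nM and 400000 nM.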

Compound 4, half-maximal inhibitory concentration: 74000 nM
The estimate for compound 4 lay 2.0-fold (0.31 log units) above the measured number; the measured number falls inside the stated range.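

In this assay compound 3 gives > 100000 nM, and this is a limit. Chloro in place of hydrogen on the aromatic carbon gives an at least 1.3-fold lower number from compound 3 to compound 4 (0.13 log units; that floor lies within the scatter); this is only a floor, so the real step may be larger, but what can be read does not show a change beyond the scatter. Going by these compounds, the same kind of change on the other core, from compound 2 to compound 1, has limits at both ends and cannot be read, so it remains unknown whether the change carries from one core to the other.

The compounds shown leave open whether another group at this place, such as an amine or a carboxylic acid, would give a lower number. They also leave open whether any compound in this series would give a number far below that of compound 4.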